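The compounds below may be only part of what the source reports. "The series", "measured", "known", "first", "only" and "open" are said of these compounds alone.

Measured so far in an assay on HEK293 cells for inhibition of Voltage-dependent N-type calcium channel subunit alpha-1B (Homo sapiens), read by patch clamp, using a membrane potential dye; on this read-out higher numbers stand for weaker inhibition and lower numbers for stronger inhibition:
compound 1 `CCOc1ccc(-c2cc(C3CC(C)(C)OC(C)(C)C3)nn2-c2ccccc2OC)cc1` gives 61 nM.
compound 2 `COc1ccccc1-n1nc([C@H]2C[C@@H](C)O[C@@H](C)C2)cc1-c1ccc(Cl)cc1` gives 91 nM.

Compound 1 shows the lower of these two numbers, and compound 2 lies within the scatter of it, so the two cannot be ranked. Compound 3 `COc1ccccc1-n1nc(C2CC(C)(C)OC(C)(C)C2)cc1-c1ccnc(Cl)c1` awaits measurement in this assay. Relative to compound 1 the change is 2-chloropyridin-4-yl in place of 4-ethoxyphenyl on an aromatic carbon. Going by the values given here, no measured pair covers this change, so no step size is known; a small move toward a weaker number, not clearly beyond the scatter, is expected. Compound 3 is estimated at 100 nM, range 40 nM to 300 nM, an expected step of a 1.6-fold higher number from compound 1 to compound 3 (0.21 log units; within the scatter).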

Compound 3, half-maximal inhibitory concentration: 740 nM
For compound 3 the middle estimate is 7.4-fold (0.87 log units) below the measured one; measured number outside the range, above it.
By their numbers in this assay, from the lowest: compounds 1 and 2 (each within the scatter of the next); then compound 3.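

In this assay, 2-chloropyridin-4-yl in place of 4-ethoxyphenyl on this aromatic carbon gives a 12-fold higher number from compound 1 to compound 3 (1.08 log units; beyond the scatter). Going by these compounds alone, this is the first measured step at this position, and it shows that the read-out is sensitive to the aromatic group placed here. Nothing available explains the size of this step.

The compounds shown do not separate the contributions of the ring nitrogen, the chlorine and the ethoxy group, as all three differ in this one change. Also open, from the compounds shown here alone, is how a pyridin-4-yl group without chlorine or a 4-ethoxypyridyl group would read at this position.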